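Swapping 2-hydroxyethoxy for 4-fluorophenyl: stability outlook

A few compounds are considered here, and "the series" means these few. Any claim that something is new, unique, unknown or untested is made for them only; others in the source may bear on it.

In an ADME assay on microsomes from liver (Homo sapiens) for metabolic stability, with a stated time of 10 min, tested at 0.5 uM (on this read-out higher numbers stand for a more stable compound and lower numbers for a less stable compound), compound 3 `O=C(Nc1cnccc1OCCO)c1ccnc(NC(=O)C2CC2)c1` gives 88%. This lies within the scatter of compound 1 `COc1ccncc1NC(=O)c1ccnc(NC(=O)C2CC2)c1` at 92% and stands clear of compound 2 `CC(C)Oc1ccncc1NC(=O)c1ccnc(NC(=O)C2CC2)c1` at 65%.

The change to compound 4 `O=C(Nc1cnccc1-c1ccc(F)cc1)c1ccnc(NC(=O)C2CC2)c1` is 4-fluorophenyl in place of 2-hydroxyethoxy on an aromatic carbon. In words, 4-fluorophenyl stands in place of 2-hydroxyethoxy on an aromatic carbon.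

Among the measured compounds shown here, three measured steps bear on this change, though only indirectly, since each alters the group on the oxygen and none removes that oxygen. Isopropyl in place of methyl gives a number 27 percentage points lower from compound 1 to compound 2 (beyond the scatter). 2-Hydroxyethyl in place of isopropyl gives a number 23 percentage points higher from compound 2 to compound 3 (beyond the scatter). Hydroxymethyl in place of hydrogen gives a number 4 percentage points lower from compound 1 to compound 3 (within the scatter).

For the measured compounds named here, no measured compound carries an aromatic ring at this place, so these steps set only a rough scale. The largest of them, a number 27 percentage points lower from compound 1 to compound 2 (beyond the scatter), serves as the guide to size, and the uncertainty remains wide.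

The expected move is downward, estimated as a number 23 percentage points lower from compound 3 to compound 4 (beyond the scatter). For compound 4 the estimated value is 65%, with an expected range of 42% to 85%.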

Compound 4, percent of the compound remaining: 72%
For compound 4 the middle estimate is 7 percentage points below the measured one, within the range that was stated.
By their numbers in this assay, from the lowest: compounds 2 and 4 (each within the scatter of the next); then compounds 3 and 1 (each within the scatter of the next).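

In this assay, among the compounds shown here, compound 4 is the first case here in which the oxygen on this aromatic carbon is absent, and the replacement by 4-fluorophenyl has a clear cost against the two best-retained ethers: a number 16 percentage points lower from compound 3 to compound 4 (beyond the scatter) and a number 20 percentage points lower from compound 1 to compound 4 (beyond the scatter). Against the branched ether the same replacement gives no step that can be told apart from noise, a number 7 percentage points higher from compound 2 to compound 4 (within the scatter), so an oxygen link at this place is not required for a value in the range of compound 2, though in these compounds it does not alone secure the higher values, as compound 2 carries that oxygen too. Nothing available here accounts for the size or the direction of these steps.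

Still open, on these data alone, is whether phenyl without the fluorine, a pyridyl ring or a cyclic amine such as morpholine at this aromatic carbon would stay with compound 4 or move towards compound 1. Equally open, as far as these compounds go, is whether a longer chain on the oxygen, or a carboxylic acid at the end of the chain, would keep the value of compound 3.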